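The compounds below may be only part of what the source reports. "The series", "measured", "known", "first", "only" and "open" are said of these compounds alone.

Working notes on the series in an ADME assay on J774 cells (Mus musculus) for cytotoxicity, read by resazurin assay, with a stated time of 72 h; a higher number here means that more compound is tolerated, a lower number that less compound is tolerated. Compound 1 `C/C(=N\Nc1nc(CCl)cs1)c1ccc(Cl)c(Cl)c1` gives > 50000 nM, a limit of the assay. Compound 2 `C/C(=N\Nc1nc(-c2ccccc2)cs1)c1ccc(Cl)c(Cl)c1` gives > 50000 nM, also a limit. Among the compounds with values here, compound 3 `C/C(=N\Nc1nc(-c2ccccn2)cs1)c1ccc(Cl)c(Cl)c1` gives 10100 nM, the only actual number so far. Next is compound 4 `C/C(=N\Nc1nc(-c2ccc(C)cc2)cs1)c1ccc(Cl)c(Cl)c1`, with 4-methylphenyl in place of pyridin-2-yl on an aromatic carbon. The nearest measured change is an at least 4.9-fold lower number from compound 2 to compound 3 (0.69 log units; beyond the scatter). A second change of the same site is an at least 4.9-fold lower number from compound 1 to compound 3 (0.69 log units; beyond the scatter). The third is a step that the two limits leave unreadable from compound 1 to compound 2. Compound 4 again carries a ring of carbon only, so a modest rise is expected, the reverse of an at least 4.9-fold lower number from compound 2 to compound 3 (0.69 log units; beyond the scatter), perhaps reaching the limit. The expected change is a 2.8-fold higher number from compound 3 to compound 4 (0.44 log units; beyond the scatter). For compound 4 the estimated value is 28000 nM, with an expected range of 11000 nM to 50000 nM.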

Compound 4, half-maximal cytotoxic concentration: > 50000 nM
Compound 4 was reported as a limit; the forecaster's own chance of this, stated with the estimate: 50%; middle value at least 1.7-fold (0.25 log units) away from the limit.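

In this assay, 4-methylphenyl in place of pyridin-2-yl on this aromatic carbon gives an at least 4.9-fold higher number from compound 3 to compound 4 (0.69 log units; beyond the scatter). Within the data shown here, a second ring of carbon only thus joins compound 2 at the limit, leaving compound 3, with its ring nitrogen, as the only compound with a number. The steps from compound 1 and compound 2 to compound 4 cannot be read: the limit of > 50000 nM in this assay, at which 3 of the 4 values shown sit.

As far as these compounds go, it remains open how far compound 1, compound 2 and compound 4 lie past the limit. From the compounds shown here alone, the effect of an amine or a carboxylic acid on the phenyl ring also remains open.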